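Ring-amine substituent in the shared core: toward compound 3

This account rests on a few compounds, and the source may have more. Where it says the series, first, only, none or still open, it means among the compounds named here.

Measured so far:
compound 1 `CCCCN1CCc2nc(C#Cc3ccccc3)sc2C1` — > 10000 nM
compound 2 `CC(C)CN1CCc2nc(C#Cc3ccccc3)sc2C1` — 650 nM

In an assay on HEK293 cells for negative allosteric modulation of metabotropic glutamate receptor 5 (Homo sapiens), read by FLIPR, with a stated time of 1 h (a higher number here means a weaker inhibitor, a lower number a stronger inhibitor), compound 1 reports a limit, > 10000 nM. Compound 2 gives 650 nM in this assay, the only number shown in the series. Among the measured compounds shown here, the one other value shown is a limit (the limit of > 10000 nM in this assay, at which 1 of the 2 values shown sits). For the measured compounds named here, the single measured step, an at least 15-fold lower number from compound 1 to compound 2 (1.18 log units; beyond the scatter), shows that branching of the chain on the ring amine nitrogen was accompanied by a large gain, though its size is bounded only on one side.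

Compound 3 `C(#Cc1nc2c(s1)CN(C1CCCCC1)CC2)c1ccccc1` is not yet measured. It differs from compound 2 in one place: cyclohexyl in place of isobutyl on an amine nitrogen in a ring. Going by the values given here, the branched-versus-linear step is the only evidence bearing on this change, and it points toward bulkier groups on this nitrogen being tolerated or favoured; a cyclohexyl is not a chain, so the carry-over is uncertain. A modest further decrease, or no step beyond the scatter, is expected. Compound 3 is therefore estimated at 350 nM in this assay, with a range from 70 nM to 1800 nM, a step of a 1.9-fold lower number from compound 2 to compound 3 (0.27 log units; within the scatter).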

Compound 3, half-maximal inhibitory concentration: > 10000 nM
Compound 3: no number, only a limit; the forecaster's own chance of this, stated with the estimate: 10%; middle value at least 28-fold (1.45 log units) from the limit.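

Cyclohexyl in place of isobutyl on an amine nitrogen in a ring gives an at least 15-fold higher number from compound 2 to compound 3 (1.18 log units; beyond the scatter) in this assay and so shows that the gain seen with the earlier branched chain does not carry over to this ring. Of the three groups shown on this nitrogen, only isobutyl gives a number, while the butyl and cyclohexyl compounds both end at a limit: the limit of > 10000 nM in this assay, at which 2 of the 3 values shown sit. The step between those two compounds cannot be read, as both values are limits.

Open, going by these compounds, is how narrow the preference around isobutyl is: a methyl, an ethyl, an isopropyl, a cyclopropylmethyl or a benzyl on this nitrogen would each test it from a different side. The compounds shown also give no cause for the loss with cyclohexyl.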